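Working notes: from compound 3 to compound 4

The source may hold more compounds than are shown below. What is called first, only, known or untested is meant among the compounds shown, and "the series" means these compounds.

Measured in a functional assay on A549 cells (Homo sapiens) for antiproliferative activity, read by MTT assay, with a stated time of 72 h; a higher number here means a weaker inhibitor, a lower number a stronger inhibitor:
- compound 1 `COc1cc(C(=O)c2sc3ccccc3c2-c2ccc(C)cc2)cc(OC)c1OC` gives 7800 nM
- compound 2 `COc1ccc(-c2c(C(=O)c3cc(OC)c(OC)c(OC)c3)sc3ccccc23)cc1` gives 4400 nM
- compound 3 `COc1ccc(-c2c(C(=O)c3cc(OC)c(OC)c(OC)c3)sc3ccccc23)c(OC)c1` gives 5800 nM

All three values lie within the scatter of one another, so no order can be drawn among them. Compound 3 sits close to both others, with a 1.3-fold higher number from compound 2 to compound 3 (0.12 log units; within the scatter) and a 1.3-fold lower number from compound 1 to compound 3 (0.13 log units; within the scatter).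

Compound 4 `CCOc1ccc(Nc2c(C(=O)c3cc(OC)c(OC)c(OC)c3)sc3ccccc23)cc1` carries a new group on the shared core: (4-ethoxyphenyl)amino in place of 2,4-dimethoxyphenyl on an aromatic carbon. The exchange falls on an aromatic carbon of the five-membered aromatic ring with 1 sulfur.

Only the changes to the aryl group bear on this, and they were small: a 1.8-fold lower number from compound 1 to compound 2 (0.25 log units; within the scatter) and a 1.3-fold lower number from compound 1 to compound 3 (0.13 log units; within the scatter). Going by the values given here, none of the measured compounds carries an amino link at this place, so the data give no direct precedent for this exchange. A modest shift is therefore expected, with its direction poorly defined and only tentatively towards a lower number. The expected change is a 1.9-fold lower number from compound 3 to compound 4 (0.29 log units; within the scatter) in this assay, which remains uncertain. For compound 4 the estimated value is 3000 nM, with an expected range from 400 nM to 12000 nM.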

Compound 4, half-maximal inhibitory concentration: 1400 nM
Beside the measured number, compound 4's estimate is 2.1-fold (0.33 log units) above it; measured number inside the range.
By their numbers in this assay, from the lowest: compound 4; then compounds 2, 3 and 1 (each within the scatter of the next).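

In this assay, going by these compounds alone, (4-ethoxyphenyl)amino at this aromatic carbon gives the only steps at this position that lie beyond the scatter: a 4.1-fold lower number from compound 3 to compound 4 (0.62 log units; beyond the scatter), a 3.1-fold lower number from compound 2 to compound 4 (0.50 log units; beyond the scatter) and a 5.6-fold lower number from compound 1 to compound 4 (0.75 log units; beyond the scatter). The earlier exchanges among directly attached aryl groups left no order, whereas compound 4 stands apart from all three of those compounds, so this position does respond to a change of substituent. No available evidence accounts for this difference.

As far as these compounds go, compound 4 differs from the others in both the amino link and the ethoxy group, so the share of each in these steps remains open. A (4-methoxyphenyl)amino group would separate the two, and a tertiary amine link carrying a methyl group would test whether the amine hydrogen matters.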